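The compounds below may be only part of what the source reports. "The series", "measured", "known", "first", "only" and "open" are said of these compounds alone.

Compound 1 `O=C1/C(=C/c2ccc(O)c(O)c2)Cc2c(O)cccc21` is the reference point of this small series. In an assay on membranes from brain for displacement of a labelled ligand from adenosine receptor A1 (Rattus norvegicus), read by radioligand binding (on this read-out lower numbers stand for stronger inhibition and higher numbers for weaker inhibition), compound 1 gives 435 nM, the lowest of the two numbers that are known here. Compound 2 `Oc1cccc(C2=CC(O)c3c(O)cccc3O2)c1`, built on a different core, gives 956 nM in this assay, a weaker result whose gap to compound 1 lies beyond the usual scatter. Compound 3 `COc1cccc2c1C/C(=C\c1ccc(N(C)C)cc1)C2=O` is reported in this assay only as a limit, > 100000 nM, and not as a number; (the limit of > 100000 nM in this assay, at which 1 of the 3 values shown sits).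

Compound 4 `COc1cccc2c1C/C(=C\c1ccc(O)c(O)c1)C2=O` has not yet been measured in this assay. Its structure differs from compound 1 in one place: methyl in place of hydrogen on an oxygen on an aromatic ring. The catechol part of the molecule is kept unchanged. For the measured compounds named here, no measured pair in this set isolates exactly this change, so the size of the step has to be estimated rather than read off. Compound 3 carries the same methoxy group on the core, but it differs from compound 1 in a second place as well, so it does not settle the question on its own.

The expectation is a modest loss in this assay, a 2.8-fold higher number from compound 1 to compound 4 (0.44 log units; beyond the scatter). Compound 4 is therefore estimated at 1200 nM in this assay, within a range from 300 nM to 6000 nM.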

Compound 4, inhibition constant: 42 nM
The estimate for compound 4 lay 29-fold (1.46 log units) above the measured number; the measured number lies below the stated range.
By their numbers in this assay, from the lowest: compound 4; then compound 1; then compound 2. At a limit, above all of these: compound 3.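

In this assay, the change from hydroxy to methoxy on the core brings a 10-fold lower number from compound 1 to compound 4 (1.02 log units; beyond the scatter) with the catechol part kept, so this position takes a methyl on the oxygen with a gain rather than a loss. For the compounds shown here, the free hydroxy hydrogen at this place is therefore not required for the binding seen in compound 1, something the earlier compounds could not show, as none of them isolated this change. The values shown include no measurement that bears on the cause of this step.

Compound 3 also carries the methoxy group, but with dimethylamino where compound 4 has the catechol part. Compound 3 is reported only as a limit of > 100000 nM and not as a number, which leaves open how far the gain at the methoxy group depends on the catechol part. Going by these compounds, whether a longer chain on this oxygen, such as ethoxy or propoxy, or an amine at the end of such a chain would extend the step or reverse it also remains open.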